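Notes on a urea-linked benzimidazolone series at the assay limit

This account rests on a few compounds, and the source may have more. Where it says the series, first, only, none or still open, it means among the compounds named here.

Measured so far:
compound 1 `CN1CCN(CCNC(=O)n2c(=O)n(Cc3ccccc3)c3ccccc32)CC1`: > 1000 nM
compound 2 `CCCCn1c(=O)n(C(=O)NCCN2CCN(C)CC2)c2ccccc21`: > 1000 nM

In an assay on isolated protein for displacement of a labelled ligand from 5-hydroxytryptamine receptor 4 (Cavia porcellus) (on this read-out higher numbers stand for weaker inhibition and lower numbers for stronger inhibition), compound 1 gives > 1000 nM, which is a limit of the assay and not a number. In this assay compound 2 gives > 1000 nM, again a limit and not a number. Compound 2 therefore stands at the limit, together with compound 1, as the limit of > 1000 nM in this assay, at which 2 of the 2 values shown sit, records. Going by the values given here, the one step between them, a step that the two limits leave unreadable from compound 1 to compound 2, cannot be read, since both ends are limits.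

The next compound, compound 3 `CN1CCN(CCNC(=O)n2c(=O)[nH]c3ccccc32)CC1`, differs from compound 2 by hydrogen in place of butyl on an aromatic nitrogen. Among the compounds with values here, no measured step bears on this change: the only step available, from compound 1 to compound 2, concerns a different position and is itself unreadable. The expectation for compound 3 in this assay therefore rests only on the fact that both measured compounds sit at the limit, so a reported limit rather than a number is the most likely outcome, and the expected step that the limit leaves unreadable from compound 2 to compound 3 is one that cannot be read against the scatter. Compound 3 is estimated at 3000 nM, within 500 nM to 20000 nM.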

Compound 3, half-maximal inhibitory concentration: 1000 nM
Beside the measured number, compound 3's estimate is 3.0-fold (0.48 log units) above it; the range from low to high includes it.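

Going by these compounds alone, with hydrogen on the aromatic nitrogen, compound 3 gives 1000 nM in this assay, the first number in this set. Compound 2, with butyl at this position, and compound 1, with benzyl at this position, gave only limits of the assay. Among these three compounds, neither butyl nor benzyl on this nitrogen yields a number, and a group at this position is not needed to reach one. Removing butyl gives a number no higher from compound 2 to compound 3 (the limit leaves the size open), and removing benzyl gives a number no higher from compound 1 to compound 3 (the limit leaves the size open). The size of neither step to compound 3 can be read, so the gain from removing either group cannot be stated: the limit of > 1000 nM in this assay, at which 2 of the 3 values shown sit.

As far as these compounds go, whether methyl or ethyl on this aromatic nitrogen would also give a number stays open, and with it how far the value tracks the size of the group here. The compounds shown also leave open how the value responds away from this position, for example to a longer chain linking the urea to the terminal amine, with hydrogen kept on the aromatic nitrogen.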